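The source may report more compounds than this note shows. Statements on the series, on what has been measured and on what is new or still open speak of the compounds shown alone.

Compound 2, whose structure is `COc1cc2nc(N3CCN(c4cc(OC(C)C)ncn4)CC3)nc(N)c2cc1OC`, is the reference point of this account. Among the measured compounds shown here, in an assay on brain for binding affinity to Adrenergic receptor alpha-1 (Rattus norvegicus) (a higher number here means a weaker inhibitor, a lower number a stronger inhibitor), compound 2 gives 0.18 nM, which is the lowest of the two numbers known so far. For the measured compounds named here, the only other measured compound is compound 1, `COc1cc2nc(N3CCN(c4ccncn4)CC3)nc(N)c2cc1OC`, and in this assay compound 1 gives 0.27 nM; the step of a 1.5-fold lower number from compound 1 to compound 2 (0.18 log units; within the scatter) lies within the scatter, so the two cannot be ordered.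

The next compound, compound 3, has the structure `COc1cc2nc(N3CCN(c4ccc(OC(C)C)nn4)CC3)nc(N)c2cc1OC`. It differs from compound 2 in a single respect: 6-isopropoxypyridazin-3-yl in place of 6-isopropoxypyrimidin-4-yl on an amine nitrogen in a ring, with the two compounds holding the same atoms, joined differently. Going by the values given here, only one measured step bears on this change, a 1.5-fold lower number from compound 1 to compound 2 (0.18 log units; within the scatter), and that step concerned the isopropoxy group rather than the aromatic ring that carries it; it was within the scatter. Among the compounds with values here, no measured step alters the ring itself, so there is no direct precedent for the change in this assay. The expectation is therefore a step of a 1.7-fold higher number from compound 2 to compound 3 (0.22 log units; within the scatter), that is, no change beyond the scatter, and compound 3 is estimated at 0.3 nM, within a range from 0.08 nM to 1.2 nM.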

Compound 3, inhibition constant: 0.29 nM
Beside the measured number, compound 3's estimate is 1.0-fold (0.01 log units) above it, within the range that was stated.
By their numbers in this assay, from the lowest: compounds 2, 1 and 3 (each within the scatter of the next).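

Among the compounds shown here, the step of a 1.6-fold higher number from compound 2 to compound 3 (0.21 log units; within the scatter) in this assay is the first measured change to the aromatic ring itself on the amine nitrogen in a ring, and 6-isopropoxypyridazin-3-yl in place of 6-isopropoxypyrimidin-4-yl, the same atoms joined differently, stays within the scatter. The step of a 1.1-fold higher number from compound 1 to compound 3 (0.03 log units; within the scatter), which brings in 6-isopropoxypyridazin-3-yl in place of pyrimidin-4-yl, also stays within the scatter, so compound 1, compound 2 and compound 3 cannot be ordered in this assay, and neither the ring change nor the isopropoxy group is shown to move the number at this position. Nothing available offers an account of why these numbers stay so close.

All three compounds carry a six-membered aromatic ring with 2 hetero atoms at this place, which leaves open how a phenyl ring, a pyridine ring or a non-aromatic ring would fare there. Isopropoxy is also the only group shown on that ring, so it remains open whether an amine, a carboxylic acid or a longer alkoxy chain would keep the number within the scatter of these three.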